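From Bromo to Methoxy: Expecting Compound 4

The compounds below may be only part of what the source reports. "The series", "measured", "known", "first", "only" and "open" are said of these compounds alone.

Compound 1 `COc1ccc(C#N)cc1COc1ccc(Cl)c(C)c1`: > 50000 nM (a limit)
Compound 2 `COc1ccc(C(N)=O)cc1/C=C\c1ccc(Cl)cc1`: 29000 nM
Compound 3 `COc1ccc(C(N)=O)cc1/C=C/c1ccc(Br)cc1`: 22000 nM

All three compounds were tested in an ADME assay on HCT-116 cells (Homo sapiens) for antiproliferative activity; on this read-out higher numbers stand for weaker inhibition and lower numbers for stronger inhibition. The entry for compound 1, > 50000 nM, is a limit and not a number. Among the measured compounds shown here, compound 3 gives 22000 nM and compound 2 gives 29000 nM, and these two readings, the only true numbers in the set, lie within the scatter of each other.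

Compound 4 `COc1ccc(/C=C/c2cc(C(N)=O)ccc2OC)cc1` has not yet been measured. It carries methoxy in place of bromo on an aromatic carbon, para to a large group (methoxy in place of bromo on an aromatic carbon). For the measured compounds named here, no measured pair shows this change, so no step beyond the scatter is expected in this assay. The estimated change is a 1.1-fold higher number from compound 3 to compound 4 (0.06 log units; within the scatter). For compound 4 the expected value is 25000 nM, within an estimated range of 9000 nM to 50000 nM.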

Compound 4, half-maximal inhibitory concentration: 19000 nM
For compound 4 the middle estimate is 1.3-fold (0.12 log units) above the measured one; measured number inside the range.
By their numbers in this assay, from the lowest: compounds 4, 3 and 2 (each within the scatter of the next). At a limit, above all of these: compound 1.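

Methoxy in place of bromo, on an aromatic carbon para to a large group, gives the first step that can be read at this position in this assay: a 1.2-fold lower number from compound 3 to compound 4 (0.06 log units; within the scatter). Replacing bromo, with no hydrogen-bond acceptor, by methoxy, with one, therefore brings no change beyond the scatter at this position. The data at hand offer no explanation for this reading.

As far as these compounds go, whether an amine or a carboxylic acid at this position would move the number beyond the scatter remains open. With this single step, no trend at this position can be drawn.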